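This account rests on a few compounds, and the source may have more. Where it says the series, first, only, none or still open, it means among the compounds named here.

Among the compounds with values here, in a functional assay on MDA-MB-231 cells (Homo sapiens) for antiproliferative activity, read by MTT assay, with a stated time of 72 h (a lower number here means a stronger inhibitor, a higher number a weaker inhibitor), compound 1 `O=C(CCc1cccc2c1B(O)OC2)Nc1ccc(F)cc1` gives 440 nM and compound 2 `CC(C)(C)OC(=O)NCc1ccc(NC(=O)CCc2cccc3c2B(O)OC3)cc1` gives 1300 nM, so compound 2 holds the higher of the two numbers measured so far. Compound 3 `O=C(CCc1cccc2c1B(O)OC2)Nc1ccc(-c2ccccc2)cc1` keeps the shared core and the amide chain of compound 2, but carries phenyl in place of ((tert-butoxycarbonyl)amino)methyl on an aromatic carbon, para to a large group: phenyl in place of ((tert-butoxycarbonyl)amino)methyl on an aromatic carbon. Within the data shown here, only one measured step bears on this change, a 3.0-fold higher number from compound 1 to compound 2 (0.47 log units; beyond the scatter), a modest step beyond the scatter at the same aromatic carbon. Among the measured compounds shown here, no phenyl compound has been measured, so this single step gives only a rough guide. A modest move back toward lower numbers is expected in this assay, smaller than that measured step. The expected change is a 1.6-fold lower number from compound 2 to compound 3 (0.21 log units; within the scatter). For compound 3 the estimated value is 800 nM, with an expected range of 250 nM to 2500 nM.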

Compound 3, half-maximal inhibitory concentration: 8800 nM
Compound 3: middle estimate off by 11-fold (1.04 log units), on the low side; the measured number lies above the stated range.
By their numbers in this assay, from the lowest: compound 1; then compound 2; then compound 3.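

In this assay, phenyl at this aromatic carbon gives a 6.8-fold higher number from compound 2 to compound 3 (0.83 log units; beyond the scatter) and, against fluoro, a 20-fold higher number from compound 1 to compound 3 (1.30 log units; beyond the scatter), so compound 3 stands as the weakest of the three. The number does not follow the heavy-atom count of the group, since phenyl has fewer heavy atoms than the ((tert-butoxycarbonyl)amino)methyl it replaces yet gives the higher number, and the ring, the hydrogen-bond donor and the acceptors all change together in this step. Nothing measured here accounts for this rise. Still open, on these data alone, is how an aminomethyl group or a carboxylic acid at this carbon would compare with fluoro, and whether chloro or methyl would keep the number near that of compound 1. As far as these compounds go, it also remains open whether a pyridine ring in place of phenyl would give a different number.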